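A few compounds are considered here, and "the series" means these few. Any claim that something is new, unique, unknown or untested is made for them only; others in the source may bear on it.

In a functional assay on NCI-H460 cells (Homo sapiens) for antiproliferative activity, read by CCK-8 assay, with a stated time of 72 h, tested at 2 uM (on this read-out lower numbers stand for a weaker effect and higher numbers for a stronger effect at the one concentration tested), compound 1 `CN1CCN(c2nc(Cl)nc3c2ncn3Cc2ccc(C(=O)Nc3ccccc3N)cc2)CC1` gives 13.5%, compound 2 `Nc1ccccc1NC(=O)c1ccc(Cn2cnc3c(Nc4ccc(-c5ccccn5)cc4)nc(Cl)nc32)cc1` gives 18.1%, and compound 3 `Nc1ccccc1NC(=O)c1ccc(Cn2cnc3c(Nc4cccc(OC(F)(F)F)c4)nc(Cl)nc32)cc1` gives 47.7%. Compound 3 thus stands highest of the three, the other two sitting well apart from it: the step of a number 34.2 percentage points higher from compound 1 to compound 3 (beyond the scatter) and the step of a number 29.6 percentage points higher from compound 2 to compound 3 (beyond the scatter) both lie beyond the scatter. Compound 4 `Nc1ccccc1NC(=O)c1ccc(Cn2cnc3c(NCc4ccccc4)nc(Cl)nc32)cc1` has not yet been measured. It differs from compound 3 in one place: benzyl in place of 3-(trifluoromethoxy)phenyl on a nitrogen on an aromatic ring. The step from compound 2 to compound 3, which also swaps the group on that nitrogen on an aromatic ring, bears most directly on this change and was modest in size; the step from compound 1 to compound 3 exchanged the whole (3-(trifluoromethoxy)phenyl)amino against 4-methylpiperazin-1-yl and was large. Both show that this position moves the read-out a great deal, and in both measured cases the 3-(trifluoromethoxy)phenyl group stood at the top. A downward step is therefore expected, estimated as a number 22.7 percentage points lower from compound 3 to compound 4 (beyond the scatter). For compound 4 the estimate is 25%, with a range from 8% to 48%.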

Compound 4, a percentage reported as inhibition, at one concentration (the size of the read-out at that concentration, not a potency): 44.7%
Estimate against measurement, compound 4: 19.7 percentage points below; the range from low to high includes it.
By their numbers in this assay, from the lowest: compounds 1 and 2 (each within the scatter of the next); then compounds 4 and 3 (each within the scatter of the next).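

Swapping the aryl group for benzyl on this nitrogen gives a number 3 percentage points lower from compound 3 to compound 4 (within the scatter) in this assay, so the 3-(trifluoromethoxy)phenyl group, which had headed both earlier comparisons, is not required for this level of read-out: benzyl, with no oxygen or fluorine, serves within the scatter of it. Benzyl also stands clear of the other two groups, with a number 26.6 percentage points higher from compound 2 to compound 4 (beyond the scatter) against 4-(pyridin-2-yl)phenyl and a number 31.2 percentage points higher from compound 1 to compound 4 (beyond the scatter) for benzylamino against 4-methylpiperazin-1-yl , so two different groups on this nitrogen now reach a level that neither of those groups reaches. No measurement at hand accounts for this.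

The compounds shown leave open how an unsubstituted phenyl, a cyclohexyl or a phenylethyl chain on this nitrogen would read. They also leave open whether a chlorine or methoxy group on the benzyl ring would change the read-out.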